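The source may report more compounds than this note shows. Statements on the series, on what has been measured and on what is new or still open speak of the compounds shown alone.

The three measured compounds, all read in a functional assay on A549 cells (Homo sapiens) for cytotoxicity, read by MTT assay, with a stated time of 72 h; a higher number here means a weaker inhibitor, a lower number a stronger inhibitor:

Compound 1 `O=C(Nc1nnc(-c2cccc(O)c2O)s1)C1CCCCC1`: 11000 nM
Compound 2 `CC(=O)Nc1nnc(-c2ccc(O)c(O)c2)s1`: 133000 nM
Compound 3 `CC(=O)Nc1nnc(-c2cccc(O)c2O)s1`: 200000 nM

Compound 2 stands second highest of the three numbers. Its value lies close to that of compound 3, within the usual scatter, while compound 1 sits far lower, beyond the scatter. Compound 4 `Cc1ccc(C(=O)Nc2nnc(-c3ccc(O)c(O)c3)s2)cc1` differs from compound 2 by 4-methylphenyl in place of methyl on a carbonyl carbon.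

Among the compounds with values here, the one measured step that bears on this change is the one on the carbonyl carbon between compound 1 and compound 3: an 18-fold higher number from compound 1 to compound 3 (1.26 log units; beyond the scatter). There a small group replacing a larger one on that carbon carried a large rise in the number. The change from compound 2 to compound 4 runs the other way, a larger group entering in place of methyl, so a large step downwards in this assay is expected for compound 4, on the order of a 10-fold lower number from compound 2 to compound 4 (1.01 log units; beyond the scatter). Compound 4 is therefore estimated at 13000 nM in this assay, with a range from 3000 nM to 60000 nM.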

Compound 4, half-maximal inhibitory concentration: 11800 nM
For compound 4 the middle estimate is 1.1-fold (0.04 log units) above the measured one, and the stated range covers the measured number.
By their numbers in this assay, from the lowest: compounds 1 and 4 (each within the scatter of the next); then compounds 2 and 3 (each within the scatter of the next).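

In this assay, the change to 4-methylphenyl gives an 11-fold lower number from compound 2 to compound 4 (1.05 log units; beyond the scatter), so a large step at this carbonyl carbon is no longer confined to a single core. Before this result, the only step at this place was an 18-fold higher number from compound 1 to compound 3 (1.26 log units; beyond the scatter), which involved cyclohexyl; now a group with an aromatic ring of carbon only also goes with a lower number than methyl, each on its own core. Nothing measured here explains why either larger group goes with the lower number.

The compounds shown leave open whether a longer chain or an amine on this carbonyl carbon would also give a number well under that of the methyl compound. They also leave open whether the methyl of the 4-methylphenyl group matters, or whether plain phenyl would read the same.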